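The source may hold more compounds than are shown below. What is called first, only, known or untested is meant among the compounds shown, and "the series" means these compounds.

Of the compounds shown here, two sharing one core have been tested in a functional assay on A549 cells (Homo sapiens) for antiproliferative activity, read by sulforhodamine B assay, with a stated time of 48 h; a higher number here means a weaker inhibitor, a lower number a stronger inhibitor. Compound 1, `COc1ccc(OC)c(/C=C/C(=O)C(=Cc2ccc(OC)c(OC)c2)C(=O)/C=C/c2cc(OC)ccc2OC)c1`, gives 400 nM in this assay. Compound 2, `COc1cc(OC)c(/C=C/C(=O)C(=Cc2ccc(O)c(OC)c2)C(=O)/C=C/c2c(OC)cc(OC)cc2OC)c(OC)c1`, gives 580 nM, the higher of the two numbers; the gap to compound 1 lies within the scatter, so these two figures do not set the compounds apart. Compound 3, `COc1cc(OC)c(/C=C/C(=O)C(=Cc2cc(OC)c(O)c(OC)c2)C(=O)/C=C/c2c(OC)cc(OC)cc2OC)c(OC)c1`, has not yet been measured in this assay. It differs from compound 2 in one place: methoxy in place of hydrogen on an aromatic carbon. The new group sits on an aromatic carbon of a six-membered aromatic ring of carbon only, ortho to a hydroxy group, turning a 4-hydroxy-3-methoxyphenyl into a 4-hydroxy-3,5-dimethoxyphenyl. Among the compounds with values here, no measured pair here shows what such an addition does, so the expectation rests on compound 2 alone, whose value of 580 nM is the only anchor. A step of a 1.0-fold higher number from compound 2 to compound 3 (0.01 log units; within the scatter) is expected, that is, none beyond the scatter in either direction. Compound 3 is therefore estimated at 600 nM in this assay, within a range from 250 nM to 1500 nM.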

Compound 3, half-maximal inhibitory concentration: 340 nM
Compound 3: middle estimate off by 1.8-fold (0.25 log units), on the high side; low and high end bracket the measured number.
By their numbers in this assay, from the lowest: compounds 3, 1 and 2 (each within the scatter of the next).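

Within the data shown here, replacing hydrogen with methoxy, which turns a 4-hydroxy-3-methoxyphenyl into a 4-hydroxy-3,5-dimethoxyphenyl, gives the first measured one-place step in this set. In this assay the result is a 1.7-fold lower number from compound 2 to compound 3 (0.23 log units; within the scatter), so on this core, at this place ortho to a hydroxy group, the methoxy group leaves the number within the usual scatter of repeated measurements. No supporting measurement is available to explain this result.

This single step cannot show whether a different group on the same aromatic carbon, such as fluorine, an amine, a carboxylic acid or a longer chain like butoxy, would move the number beyond the scatter. It also leaves open whether adding the same methoxy group would give a similar result on a compound whose ring carries no hydroxy group, or on a core with different groups on its other two aromatic rings.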